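The source may hold more compounds than are shown below. What is called first, only, known or untested is meant among the compounds shown, and "the series" means these compounds.

In an ADME assay on J774.A1 cells (Mus musculus) for cytotoxicity, with a stated time of 48 h (on this read-out higher numbers stand for lower toxicity in this test and lower numbers for higher toxicity in this test), compound 1 `FC(F)(F)c1ccc(OC2C(Cn3ccnc3)CCCC2Cn2ccnc2)cc1` gives 94.5 ug/mL. Compound 2 `O=[N+]([O-])c1ccc(OC2C(Cn3ccnc3)CCCC2Cn2ccnc2)cc1`, which carries the change (nitro in place of trifluoromethyl on an aromatic carbon), gives 73.9 ug/mL in this assay, so that the step of a 1.3-fold lower number from compound 1 to compound 2 (0.11 log units; within the scatter). Compound 3 `FC(F)(F)c1ccc(OC2C(n3ccnc3)CCCC2n2ccnc2)cc1` gives 96.4 ug/mL in this assay; the difference between its core and the core of compound 1 is not broken down here, and its value and those of compound 1 and compound 2 lie within the scatter of one another. Compound 4 `O=[N+]([O-])c1ccc(OC2C(n3ccnc3)CCCC2n2ccnc2)cc1` has not yet been measured in this assay. It differs from compound 3 by nitro in place of trifluoromethyl on an aromatic carbon, the same change that separates compound 1 from compound 2, and this change occurs twice among the four compounds shown. Because the earlier step of a 1.3-fold lower number from compound 1 to compound 2 (0.11 log units; within the scatter) did not leave the scatter, a step of about the same size is expected here, namely a 1.3-fold lower number from compound 3 to compound 4 (0.10 log units; within the scatter). On that basis compound 4 is estimated to give 76 ug/mL in this assay, with a likely range from 48 ug/mL to 120 ug/mL.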

Compound 4, half-maximal cytotoxic concentration: > 100 ug/mL
Compound 4: no number, only a limit; the forecaster's own chance of this, stated with the estimate: 5%; middle value at least 1.3-fold (0.11 log units) away from the limit.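

In this assay compound 4 gives > 100 ug/mL, which is a limit of the assay and not a number: the limit of > 100 ug/mL in this assay, at which 1 of the 4 values shown sits.

On the core of compound 3, nitro in place of trifluoromethyl on an aromatic carbon therefore gives only a floor for the step, an at least 1.0-fold higher number from compound 3 to compound 4 (0.01 log units; that floor lies within the scatter). The result does not show that the change carries from one core to the other with the same size, and it does not show that the size differs: the same change on two cores in this assay, a 1.3-fold lower number (0.11 log units; within the scatter) from compound 1 to compound 2 and an at least 1.0-fold higher number (0.01 log units; that floor lies within the scatter) from compound 3 to compound 4; the limit leaves it open whether they differ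

The compounds shown leave open how far the value of compound 4 lies past the limit, and so how the change truly compares across the two cores. They also leave open what other groups on that aromatic carbon, such as a chlorine atom, a methoxy group, an amine or a carboxylic acid, would give in this assay on either core.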